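Extending the Propyl Chain of Compound 2 to Pentyl

A few compounds are considered here, and "the series" means these few. Any claim that something is new, unique, unknown or untested is made for them only; others in the source may bear on it.

Among the compounds with values here, in an ADME assay on BALB/3T3 cells (Mus musculus) for cytotoxicity, read by sulforhodamine B assay, with a stated time of 72 h (on this read-out higher numbers stand for weaker inhibition and lower numbers for stronger inhibition), only two compounds have numbers so far. Compound 1 `CC(=O)N[C@@H](CSC(=S)NCCCCNC(=S)SC[C@H](NC(C)=O)C(=O)O)C(=O)O` gives 5540 nM and compound 2 `CCCNC(=S)SC[C@H](NC(C)=O)C(=O)O` gives 224000 nM as the higher of the two numbers, so it stands at the weak end, and the gap between them lies beyond the usual scatter. Compound 3 `CCCCCNC(=S)SC[C@H](NC(C)=O)C(=O)O` has not yet been measured. Against compound 2 it carries ethyl in place of hydrogen on a saturated chain carbon, three bonds along the chain from an amide-type nitrogen and in words this is ethyl in place of hydrogen on a saturated chain carbon, three bonds along the chain from an amide-type nitrogen, so that propyl becomes pentyl. Within the data shown here, no measured pair differing in one place is available as a guide, so any expectation is loose. Among the measured compounds shown here, compound 1 at 5540 nM holds the only lower number, but it differs from compound 2 in more than one place and hints at a direction only weakly. A modest move toward stronger inhibition is expected, an estimated 2.0-fold lower number from compound 2 to compound 3 (0.31 log units; beyond the scatter) that would sit around the edge of the scatter. For compound 3 the expected value is 110000 nM (estimated range 45000 nM to 260000 nM).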

Compound 3, half-maximal inhibitory concentration: 48500 nM
For compound 3 the middle estimate is 2.3-fold (0.36 log units) above the measured one; low and high end bracket the measured number.
By their numbers in this assay, from the lowest: compound 1; then compound 3; then compound 2.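

In this assay, within the data shown here, the change of propyl to pentyl gives the first step here that can be read at a single place (a 4.6-fold lower number from compound 2 to compound 3 (0.66 log units; beyond the scatter)). It shows that on a saturated chain carbon, three bonds along the chain from an amide-type nitrogen, ethyl in place of hydrogen moves the read-out toward stronger inhibition by more than the usual scatter, something compound 1 and compound 2 could not show, as they differ in more than one place. Nothing measured here accounts for the size of this step or says what the added ethyl does.

With a single step at this position, the compounds shown leave open whether a longer chain such as heptyl would carry the move toward stronger inhibition further or end it, and so whether this step is part of any trend. They also leave open how an amine or a carboxylic acid in place of the ethyl, at the same place on the shared core, would read in this assay and whether such a group would keep the direction seen with pentyl.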